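Dimethylamino to Diethylamino on a Shorter Chain

The source may report more compounds than this note shows. Statements on the series, on what has been measured and on what is new or still open speak of the compounds shown alone.

Compound 1 `CN(C)CCCn1c(N)c(-c2nc3ccccc3[nH]2)c2nc(C#N)c(C#N)nc21` and compound 2 `CCN(CC)CCCn1c(N)c(-c2nc3ccccc3[nH]2)c2nc(C#N)c(C#N)nc21` share one core and differ in one place: diethylamino in place of dimethylamino on a saturated chain carbon, three bonds along the chain from an aromatic nitrogen. In a functional assay on HL60/MX2 cells (Homo sapiens) for antiproliferative activity, read by MTT assay, with a stated time of 48 h (on this read-out lower numbers stand for stronger inhibition and higher numbers for weaker inhibition), compound 1 gives 2390 nM, and compound 2 gives 1820 nM, so the step is a 1.3-fold lower number from compound 1 to compound 2 (0.12 log units; within the scatter). Compound 3 `CN(C)CCn1c(N)c(-c2nc3ccccc3n2C)c2nc(C#N)c(C#N)nc21` has the same atoms as compound 1 joined differently; the difference between the two cores is not broken down here. In this assay compound 3 gives 4680 nM, the highest of the three numbers, though its gap to compound 1 lies within the scatter while its gap to compound 2 lies beyond it. Compound 4 `CCN(CC)CCn1c(N)c(-c2nc3ccccc3n2C)c2nc(C#N)c(C#N)nc21` has not yet been measured; it differs from compound 3 by diethylamino in place of dimethylamino on a saturated chain carbon, two bonds along the chain from an aromatic nitrogen. This is the same kind of change as that from compound 1 to compound 2, not the same, since the place differs: there the amine sits three bonds along the chain from the aromatic nitrogen, here two bonds. Because the earlier step was a 1.3-fold lower number from compound 1 to compound 2 (0.12 log units; within the scatter), the step from compound 3 to compound 4 is expected to be small, about a 1.3-fold lower number from compound 3 to compound 4 (0.11 log units; within the scatter). For compound 4 the estimated value in this assay is 3600 nM, between 1800 nM and 7200 nM.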

Compound 4, half-maximal inhibitory concentration: 3250 nM
Compound 4: the middle estimate sits 1.1-fold (0.04 log units) above what was measured, and the stated range covers the measured number.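

In this assay, diethylamino in place of dimethylamino on the core of compound 3 gives a 1.4-fold lower number from compound 3 to compound 4 (0.16 log units; within the scatter), so the difference cannot be told apart from the ordinary spread of repeated measurements. Set beside the earlier step, the result on this core agrees with the one on the core of compound 1: the same change on two cores in this assay, a 1.3-fold lower number (0.12 log units; within the scatter) from compound 1 to compound 2 and a 1.4-fold lower number (0.16 log units; within the scatter) from compound 3 to compound 4, 1.1-fold (0.04 log units) apart, within the scatter of two such steps. This shows that, on these two cores, the swap between these two amines carries over without a step beyond the scatter, but it does not establish a real gain from diethylamino, and two cores cannot speak for every core in the series.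

What the compounds shown leave open is whether a ring amine such as morpholine or piperidine, put in place of these two amines, would give a step beyond the scatter. Going by these compounds alone, they also leave open how a longer chain carrying diethylamino would behave, and no pair here differs in chain length alone.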